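The compounds below may be only part of what the source reports. "The series", "measured", "known", "first", "only" and "open" are said of these compounds alone.

Measured so far:
Compound 1, `CCC/C(C)=N\Nc1nc(-c2cccc([N+](=O)[O-])c2)cs1`, gives 1040000 nM in a functional assay, with a stated time of 16 h; on this read-out higher numbers stand for weaker inhibition and lower numbers for stronger inhibition.
Compound 2, `C/C(CC(C)C)=N/Nc1nc(-c2cccc([N+](=O)[O-])c2)cs1`, gives 1050000 nM in this assay.

Both compounds share the same core and differ only in the shape of the saturated chain hanging off the carbon that carries the double bond to nitrogen. The change between them, a 1.0-fold higher number from compound 1 to compound 2 (0.00 log units; within the scatter), left the read-out essentially where it was, so compound 2 stands alongside compound 1 with the two numbers within the scatter of each other; neither can be called stronger or weaker.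

Compound 3, `CCCCCC/C(C)=N\Nc1nc(-c2cccc([N+](=O)[O-])c2)cs1`, is the next variation on the same theme. Compared with compound 2 the change is pentyl in place of isopropyl on a saturated chain carbon bound to a carbon with a double bond to nitrogen. Within the data shown here, only one measured step touches this part of the molecule, the step from compound 1 to compound 2, and it altered the chain without moving the number beyond the scatter. Chain shape therefore appears to matter little here, and on that basis no step beyond the scatter is expected in this assay for compound 3. The step expected here is a 1.1-fold lower number from compound 2 to compound 3 (0.02 log units; within the scatter). Compound 3 is estimated at 1000000 nM, with a likely range from 300000 nM to 3500000 nM.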

Compound 3, half-maximal inhibitory concentration: 1110000 nM
Beside the measured number, compound 3's estimate is 1.1-fold (0.05 log units) below it, within the range that was stated.
By their numbers in this assay, from the lowest: compounds 1, 2 and 3 (each within the scatter of the next).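

The earlier pair changed the chain only by a methyl in place of hydrogen, whereas this result tests a larger exchange at the same part of the molecule. Pentyl in place of isopropyl, on a saturated chain carbon bound to a carbon with a double bond to nitrogen, gives a 1.1-fold higher number from compound 2 to compound 3 (0.02 log units; within the scatter) in this assay, and propyl in place of hydrogen, three bonds along the chain from that carbon, gives a 1.1-fold higher number from compound 1 to compound 3 (0.03 log units; within the scatter) in the same read-out, so neither the branched end nor the added carbons separate these three compounds in this assay. No measurement is available that could explain this flat result.

From the compounds shown here alone, all three compounds carry plain saturated chains, so it remains open whether an amine or a carboxylic acid at the end of the chain, a ring such as phenyl, or a much longer chain such as dodecyl would move the number beyond the scatter. Going by these compounds, it is also open whether changes elsewhere on the shared core, such as replacing the nitro group, would matter more than this chain does.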